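Swapping 3-methylphenyl for pyridin-2-yl on compound 2

A few compounds are considered here, and "the series" means these few. Any claim that something is new, unique, unknown or untested is made for them only; others in the source may bear on it.

Going by the values given here, only three compounds in this small set have been measured so far in a physicochemical assay for solubility, read by turbidimetry, measured as kinetic solubility, at pH 7.4; a lower number here means a less soluble compound, a higher number a more soluble compound. Compound 1 `COc1ccccc1N1C(=O)CSC1c1cc(F)cc(C(=O)NCCCCc2ccccc2)c1` gives 10000 nM and compound 2 `Cc1cccc(N2C(=O)CSC2c2cccc(C(=O)NCCCCc3ccccc3)c2)c1` gives 10000 nM, so these two stand level, together at the low end of the three numbers. Compound 3 `Cc1ccnc(N2C(=O)CSC2c2cccc(C(=O)NCCCCn3cccn3)c2)c1` gives 50000 nM, a higher number and a gap well beyond the usual scatter.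

The unmeasured compound 4 `O=C(NCCCCc1ccccc1)c1cccc(C2SCC(=O)N2c2ccccn2)c1` keeps all of compound 2 except one group: pyridin-2-yl in place of 3-methylphenyl on an amide-type nitrogen in a ring. Here pyridin-2-yl stands in place of 3-methylphenyl on an amide-type nitrogen in a ring.

Among the compounds with values here, no two measured compounds differ in just one place, so this swap has no direct precedent. Compound 3 is the closest guide, with a hetero atom in the aromatic ring on that same nitrogen. It also carries a different side chain, however, so its 50000 nM cannot be credited to that ring alone. A modest rise in this assay is therefore expected, one that may not clear the scatter. The estimated step is a 1.5-fold higher number from compound 2 to compound 4 (0.18 log units; within the scatter). For compound 4 the expected value is 15000 nM, with an estimated range from 7000 nM to 40000 nM.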

Compound 4, solubility: 20000 nM
Compound 4: middle estimate off by 1.3-fold (0.12 log units), on the low side; measured number inside the range.
By their numbers in this assay, from the lowest: compounds 1, 2 and 4 (each within the scatter of the next); then compound 3.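

Going by these compounds alone, this pair gives the first one-place comparison in the set, and so the first direct reading of a change on the amide-type nitrogen in the ring: in this assay, putting pyridin-2-yl in place of 3-methylphenyl gives a 2.0-fold higher number from compound 2 to compound 4 (0.30 log units; within the scatter) and stays within the usual scatter of repeated measurements. The swap replaces a six-membered aromatic ring of carbon only with one that holds a hetero atom and a hydrogen-bond acceptor, yet this assay cannot separate the two compounds, so this single pair shows no clear effect of the change at this position. Nothing measured here gives a reason for this result, and a single pair cannot show whether a real but small difference lies inside the scatter.

On these data alone, it remains open whether a ring with a second nitrogen, such as pyrimidin-2-yl, or a pyridin-2-yl carrying an amine, would produce a step beyond the scatter on this nitrogen. Also open, as far as these compounds go, is whether a carboxylic acid on the side chain of compound 4 would shift this reading further than any change to the ring on the nitrogen.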